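Shifting a methoxyphenyl group on a compound without recorded activity

The source may report more compounds than this note shows. Statements on the series, on what has been measured and on what is new or still open speak of the compounds shown alone.

Compound 1 `Cc1c(OC[C@@H](C)COc2ccc(F)c(C(=O)O)c2)ccc(C(=O)CC(C)(C)C)c1O` gives 1180 nM in an assay for positive allosteric modulation of metabotropic glutamate receptor 3 (Rattus norvegicus); a lower number here means that less compound is needed, a higher number that more compound is needed for the effect. A single exchange on an aromatic carbon brought an at least 8.4-fold higher number from compound 1 to compound 2 (0.92 log units; beyond the scatter). For compound 2 `Cc1ccc(OC[C@H](C)COc2ccc(C(=O)CC(C)(C)C)c(O)c2C)cc1C(=O)O` the recorded value in this assay, > 10000 nM, is a limit of the assay rather than a number. Compound 3 `COc1ccccc1OC[C@H](C)COc1ccc(C(=O)CC(C)(C)C)c(O)c1C` is reported in this assay as "not active" (no number reported), so no number stands for it; of the three results given, compound 3 has none, and one further result is the limit of > 10000 nM in this assay, at which 1 of the 3 values shown sits. Compound 4 `COc1cccc(OC[C@H](C)COc2ccc(C(=O)CC(C)(C)C)c(O)c2C)c1` differs from compound 3 by 3-methoxyphenyl in place of 2-methoxyphenyl on an oxygen on a saturated carbon. For the measured compounds named here, no measured step touches the methoxyphenyl pair, and the one measured step concerns fluoro and methyl on a different part of the molecule, so it does not bear directly on this change; compound 3 itself offers no number from which a step could be reckoned. Compound 4 is therefore expected to show no measurable potency in this assay either, estimated at 12000 nM within a range of 3000 nM to 50000 nM, and most probably reported only as a limit.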

Compound 4, half-maximal effective concentration: "not active" (no number reported)
Compound 4: no number reported; the estimate stays without a comparison.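

Compound 3 and compound 4 are both reported as "not active" in this assay, with no number for either, so no new step can be read between them, and nothing else shown bears on this result. The compounds shown leave open whether 2-methoxyphenyl and 3-methoxyphenyl differ at all in this assay.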